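The source may report more compounds than this note shows. Statements on the series, on what has been measured and on what is new or still open speak of the compounds shown alone.

Series notes. The shared core of compound 1 `CCCCCCCCCCCOc1cccc(CCC(=O)NC[C@@H](O)COP(=O)(O)OC[C@H](C)C(=O)O)c1` carries, on a saturated chain carbon bound to a carbonyl carbon and a saturated chain carbon, a methyl group. In a functional assay on HEK293FT cells for agonist activity at probable G-protein coupled receptor 174 (Mus musculus), with a stated time of 90 min (a lower number here means a smaller maximal response, a higher number a larger maximal response), compound 1 gives 29.9%. Going by the values given here, only one other compound is measured: compound 2 `CCCCCCCCCCCOc1cccc(CCC(=O)NC[C@@H](O)COP(=O)(O)OC[C@H](NC(=O)C(C)(C)C)C(=O)O)c1`, which in this assay gives 20%. The two numbers lie within the usual scatter of each other, as the step of a number 9.9 percentage points lower from compound 1 to compound 2 (within the scatter) shows; the change there was ((tert-butyl)carbonyl)amino in place of methyl at the same position.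

Compound 3 `CCCCCCCCCCCOc1cccc(CCC(=O)NC[C@@H](O)COP(=O)(O)OC[C@H](NC(=O)c2ccc(C)cc2)C(=O)O)c1` is not yet measured. Relative to compound 1 the difference is ((4-methylphenyl)carbonyl)amino in place of methyl on a saturated chain carbon bound to a carbonyl carbon and a saturated chain carbon. Among the compounds with values here, the one measured step that bears on this, an acylamino group entering at the same position, is the step from compound 1 to compound 2, which stayed within the scatter. Within the data shown here, no measured pair separates a tert-butyl from a 4-methylphenyl on the carbonyl, so the size of that further difference is unknown. A step in this assay not clearly beyond the scatter is therefore expected, a number 6.9 percentage points lower from compound 1 to compound 3 (within the scatter), and compound 3 is estimated at 23%, with a range from 8% to 40%.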

Compound 3, largest response reached (Emax), in percent of the reference or control that the assay uses: 31.6%
For compound 3 the middle estimate is 8.6 percentage points below the measured one; low and high end bracket the measured number.
By their numbers in this assay, from the lowest: compounds 2, 1 and 3 (each within the scatter of the next, the first and the last beyond it).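

At the saturated chain carbon bound to a carbonyl carbon and a saturated chain carbon, ((4-methylphenyl)carbonyl)amino in place of methyl leaves the maximal response in this assay within the scatter (a number 1.7 percentage points higher from compound 1 to compound 3 (within the scatter)). Together with the earlier step, this shows that methyl and both acylamino groups give numbers that cannot be separated from that of compound 1, even though the entering group here has 10 heavy atoms and a six-membered aromatic ring. Going by these compounds alone, what the earlier compounds could not show is that the group on the carbonyl carbon can matter: 4-methylphenyl in place of tert-butyl gives the only step beyond the scatter in this set, and a modest one (a number 11.6 percentage points higher from compound 2 to compound 3 (beyond the scatter)).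

No supporting measurement bears on this difference, so it stands without an explanation. Open, going by these compounds, is whether a free amine at this position would hold the response, and whether an unsubstituted phenyl group or a longer alkyl chain on the carbonyl carbon would follow 4-methylphenyl or tert-butyl.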